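The source may hold more compounds than are shown below. What is called first, only, known or untested is meant among the compounds shown, and "the series" means these compounds.

Measured so far in a physicochemical assay for lipophilicity, at pH 7.4; on this read-out higher numbers stand for higher lipophilicity and lower numbers for lower lipophilicity:
- compound 1 `CCc1ccc(N(Cc2ccccc2)S(=O)(=O)c2ccc3c(c2)C(=O)CC(C2CCOCC2)O3)cc1` gives 4.84
- compound 2 `CCc1ccc(N(CC(C)C)S(=O)(=O)c2ccc3c(c2)C(=O)N(C2CCOCC2)C3)cc1` gives 3.64
- compound 3 `CCc1ccc(N(CC(C)C)S(=O)(=O)c2ccc3cc(OCC4CCOCC4)c(C(=O)OCC4CCOCC4)cc3c2)cc1` gives 6.34

Among these three numbers compound 1 holds the second highest place. Its nearest neighbour is compound 2, which lies well below it, beyond the usual scatter, and its furthest is compound 3, which lies even further above it, also beyond the scatter. Among the measured compounds shown here, none of these three compounds differs from another in only one place, so no single step between measured compounds is at hand to lean on.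

Compound 4 `CCc1ccc(N(C2COC2)S(=O)(=O)c2ccc3c(c2)C(=O)CC(C2CCOCC2)O3)cc1` has not yet been measured in this assay. It differs from compound 1 in one place: oxetan-3-yl in place of benzyl on a sulfonamide nitrogen. For the measured compounds named here, with no matched pair to compare, the expectation rests on the exchange itself, and a clear step downward in this assay, well beyond the scatter, is expected. The step from compound 1 to compound 4 is estimated to be a number 2.04 log units lower from compound 1 to compound 4 (beyond the scatter). Compound 4 is therefore expected to come out near 2.8, most likely between 2.1 and 3.5.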

Compound 4, distribution coefficient: 2.72
For compound 4 the middle estimate is 0.08 log units above the measured one; the range from low to high includes it.
By their numbers in this assay, from the lowest: compound 4; then compound 2; then compound 1; then compound 3.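

In this assay the exchange of benzyl for oxetan-3-yl on the sulfonamide nitrogen gives a number 2.12 log units lower from compound 1 to compound 4 (beyond the scatter), so this one position alone can shift the read-out by a large amount. The earlier compounds shown here could not show this, since they differ from one another in several places at once, whereas here the rest of the molecule stays the same and the whole step belongs to this single exchange. No measurement shown explains the size of the step.

The exchange removes an aromatic ring of carbon only and brings in a smaller ring containing oxygen, and a cyclobutyl group, a four-membered ring of carbon only, would be needed to begin separating ring size from the ring oxygen. Going by these compounds, whether the same exchange gives a similar step on a different core also remains open.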